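The source may hold more compounds than are shown below. What is called first, only, known or untested is meant among the compounds shown, and "the series" means these compounds.

Compound 1 `COc1cccc(OC)c1C(=O)Nc1c[nH]nc1C(=O)N[C@H]1CC[C@H](O)CC1`: in an ADME assay on MRC5 cells (Homo sapiens) for inhibition, with a stated time of 72 h (a lower number here means that less compound is needed, a higher number that more compound is needed for the effect), compound 1 gives 34000 nM.
Compound 2 `COc1cccc(OC)c1C(=O)Nc1c[nH]nc1C(=O)NN1CCOCC1`: compound 2 gives only a limit of the assay, > 50000 nM.
Compound 3 `COc1cccc(OC)c1C(=O)Nc1c[nH]nc1C(=O)NCc1ncccc1C`: compound 3 likewise gives only a limit of the assay, > 50000 nM.

Compound 3 thus stands at the edge of what this assay can report, a position shared with one other value shown (the limit of > 50000 nM in this assay, at which 2 of the 3 values shown sit). Compound 4 `COc1cccc(OC)c1C(=O)Nc1c[nH]nc1C(=O)NCCCN(C)C` differs from it in one place: 2-(dimethylamino)ethyl in place of 3-methylpyridin-2-yl on a saturated chain carbon bound to an amide-type nitrogen. Going by the values given here, two measured steps touch compound 3. The step of an at least 1.4-fold higher number from compound 1 to compound 3 (0.16 log units; that floor lies within the scatter) ran into the limit, and the step that the two limits leave unreadable from compound 2 to compound 3 runs from one limit to another. Neither has a readable size, so no step beyond the scatter is expected for compound 4, and its number may again be a limit. The estimate for compound 4 is 50000 nM, between 20000 nM and 100000 nM, which means an expected step of a number no higher from compound 3 to compound 4 (the limit leaves the size open).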

Compound 4, half-maximal effective concentration: > 50000 nM
Compound 4: only a limit was reported; the forecaster's own chance of this, stated with the estimate: 60%; the middle value lies on the limit itself.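

In this assay, compound 4 also gives only a limit, > 50000 nM, and its 3-(dimethylamino)propyl group has no ring, unlike the groups on this amide-type nitrogen in compounds 1 to 3. Going by these compounds alone, the only readable comparison is an at least 1.4-fold higher number from compound 1 to compound 4 (0.16 log units; that floor lies within the scatter), while the steps from compound 2 and from compound 3 to compound 4 cannot be read. A ring-free chain with an amine at its end thus lands at the same edge of the assay: the limit of > 50000 nM in this assay, at which 3 of the 4 values shown sit.

As far as these compounds go, how far these compounds lie past the limit stays open. Also open, from the compounds shown here alone, is whether a carboxylic acid or a simple hydroxyethyl chain on this nitrogen would give a readable number, as compound 1 does.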